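A few compounds are considered here, and "the series" means these few. Any claim that something is new, unique, unknown or untested is made for them only; others in the source may bear on it.

Measured in a functional assay on NCI-H460 cells (Homo sapiens); a lower number here means that less compound is needed, a higher number that more compound is needed for the effect:
- compound 1 `COc1cc(C2OC(c3ccc(N(C)C)cc3)=NN2C(C)=O)cc(OC)c1OC`: 0.044 uM
- compound 2 `COc1ccc(C2OC(c3ccc(N(C)C)cc3)=NN2C(C)=O)cc1OC`: 5.1 uM

Compound 1 holds the lower of the two numbers, and the gap is large: a 120-fold higher number from compound 1 to compound 2 (2.06 log units; beyond the scatter). The unmeasured compound 3 `COc1cc(C2OC(c3ccc(N(C)C)cc3)=NN2C(=O)CO)cc(OC)c1OC` keeps the core of compound 1 and differs from it in one place: hydroxy in place of hydrogen on a saturated chain carbon bound to a carbonyl carbon. Put another way, acetyl becomes (hydroxymethyl)carbonyl.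

Within the data shown here, no measured step touches this place. Among the measured compounds shown here, the only step available replaces methoxy with hydrogen on an aromatic carbon, so it bears on compound 3 only indirectly. That step, a 120-fold higher number from compound 1 to compound 2 (2.06 log units; beyond the scatter), shows that a single change can move the number a long way in this assay, but it gives no size for a change at the acetyl. For the measured compounds named here, compound 1 gives 0.044 uM, the better of only two numbers, so a modest rise seems more likely than a fall, though the data cannot settle the direction. The expected change is a 2.3-fold higher number from compound 1 to compound 3 (0.36 log units; beyond the scatter), far smaller than the measured step. For compound 3 the estimated value is 0.1 uM, with an expected range from 0.02 uM to 0.6 uM.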

Compound 3, concentration for half-maximal effect: 0.043 uM
Estimate against measurement, compound 3: 2.3-fold (0.37 log units) above; measured number inside the range.
By their numbers in this assay, from the lowest: compounds 3 and 1 (each within the scatter of the next); then compound 2.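

In this assay, the first step read at the acetyl, methyl to hydroxymethyl, is a 1.0-fold lower number from compound 1 to compound 3 (0.01 log units; within the scatter) and leaves compound 1 and compound 3 indistinguishable. Among these compounds, the one earlier step, on an aromatic carbon, was a 120-fold higher number from compound 1 to compound 2 (2.06 log units; beyond the scatter) and gave no reading for this place; the new step shows that, on the core of compound 1, a hydroxy on the saturated chain carbon bound to a carbonyl carbon is compatible with a number as low as that of compound 1. The sensitivity seen at the methoxy therefore does not carry over to this change at the acetyl, although a single step cannot describe this place in general, and nothing available explains the result.

The compounds shown leave open whether an amine, a carboxylic acid or a longer chain on this same carbon would also stay within the scatter of compound 1, or whether the range of groups accepted here ends with hydroxymethyl. They also leave open whether (hydroxymethyl)carbonyl would read the same on the core of compound 2, which lacks the methoxy, and whether the match between compound 1 and compound 3 holds on cells other than those of this assay.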